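The source may report more compounds than this note shows. Statements on the series, on what has been measured and on what is new or still open speak of the compounds shown alone.

Measured in a functional assay on MCF7 cells (Homo sapiens) for cytotoxicity, read by MTT assay, with a stated time of 24 h; a higher number here means a weaker inhibitor of growth, a lower number a stronger inhibitor of growth:
- Compound 1 `COc1ccc(/C=C/C(=O)c2ccc(OCC=C(C)C)cc2O)cc1`: 97500 nM
- Compound 2 `COc1ccc(/C=C/C(=O)c2ccc(OCC=C(C)C)cc2O)c(OC)c1OC`: > 100000 nM (a limit, not a number)
- Compound 3 `COc1ccc(/C=C/C(=O)c2ccc(OCC=C(C)C)cc2O)cc1OC`: > 100000 nM (a limit, not a number)

Compound 3 has no exact number and stands at a limit of the assay, > 100000 nM. Compound 2 is also reported only as a limit, and the set as a whole is summed up by the limit of > 100000 nM in this assay, at which 2 of the 3 values shown sit.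

Compound 4 `COc1cc(/C=C/C(=O)c2ccc(OCC=C(C)C)cc2O)cc(OC)c1OC` differs from compound 3 by a single change: methoxy in place of hydrogen on an aromatic carbon.

Going by the values given here, two measured steps bear on this change. Among the compounds with values here, the one with the same swap of methoxy for hydrogen is an at least 1.0-fold higher number from compound 1 to compound 3 (0.01 log units; that floor lies within the scatter). The one that runs the other way, hydrogen for methoxy, is a step that the two limits leave unreadable from compound 2 to compound 3. Neither gives a size that can be carried over, so no step beyond the scatter is expected in this assay, and no direction can be favoured. A further limit would be no surprise.

The estimated step is a number no higher from compound 3 to compound 4 (the limit leaves the size open). For compound 4 the expected value is 100000 nM. The estimated range for compound 4 runs from 50000 nM to 200000 nM.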

Compound 4, concentration for 50% growth inhibition: 81000 nM
Compound 4: middle estimate off by 1.2-fold (0.09 log units), on the high side; the measured number falls inside the stated range.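

In this assay, adding methoxy at this position, ortho to a methoxy group and meta to a methoxy group, gives an at least 1.2-fold lower number from compound 3 to compound 4 (0.09 log units; that floor lies within the scatter). As far as these compounds go, compound 3 is reported only as a limit, so that floor is all that can be read and the true size of the step stays open, but the change does turn a limit into an exact number. Even so, the set as a whole is still summed up by a limit: the limit of > 100000 nM in this assay, at which 2 of the 4 values shown sit.

From the compounds shown here alone, what a different group at this position, such as an amine, a hydroxyl or a longer chain like ethoxy, would do remains open. Also open, going by these compounds, is whether this methoxy would give a step beyond the scatter on a core whose values do not sit at a limit.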